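The source may hold more compounds than are shown below. What is called first, only, known or untested is meant among the compounds shown, and "the series" means these compounds.

Compound 1 `O=c1cc(Cn2ccnc2)c2ccc(OCc3cccc(Cl)c3)cc2o1` is one of three measured compounds that share a core and differ only in the group on the saturated chain carbon bound to an oxygen on an aromatic ring. In an assay on V79MZh11B1 cells for inhibition of cytochrome P450 11B1, mitochondrial (Homo sapiens), read by HPLC, with a stated time of 25 min (a lower number here means a stronger inhibitor, a higher number a weaker inhibitor), compound 1 gives 31 nM, which is the second highest of the three numbers. Compound 2 `O=c1cc(Cn2ccnc2)c2ccc(OCc3cccc(C(F)(F)F)c3)cc2o1` gives 20 nM in this assay, and compound 3 `COc1ccc(COc2ccc3c(Cn4ccnc4)cc(=O)oc3c2)cc1OC` gives 57 nM. All three values lie close together: the step from compound 1 to compound 2 is a 1.6-fold lower number from compound 1 to compound 2 (0.19 log units; within the scatter), and the gap between compound 1 and compound 3 is likewise within the scatter. Compound 4 `O=c1cc(Cn2ccnc2)c2ccc(OCc3cc(F)cc(F)c3)cc2o1` has not yet been measured in this assay. It differs from compound 1 by 3,5-difluorophenyl in place of 3-chlorophenyl on a saturated chain carbon bound to an oxygen on an aromatic ring. For the measured compounds named here, the only measured step that bears on this change is a 1.6-fold lower number from compound 1 to compound 2 (0.19 log units; within the scatter), where exchanging one halogen-type substituent on the phenyl for another left the number within the scatter. On that basis no step beyond the scatter is expected, so the estimate for compound 4 is 35 nM, with a range from 15 nM to 80 nM. This estimate means an expected step of a 1.1-fold higher number from compound 1 to compound 4 (0.05 log units; within the scatter).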

Compound 4, half-maximal inhibitory concentration: 45 nM
Compound 4: middle estimate off by 1.3-fold (0.11 log units), on the low side; low and high end bracket the measured number.
By their numbers in this assay, from the lowest: compounds 2, 1, 4 and 3 (each within the scatter of the next, the first and the last beyond it).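

In this assay, 3,5-difluorophenyl in place of 3-chlorophenyl gives a 1.5-fold higher number from compound 1 to compound 4 (0.16 log units; within the scatter). The earlier step, a 1.6-fold lower number from compound 1 to compound 2 (0.19 log units; within the scatter), exchanged one group on the phenyl for another, whereas this change alters both the kind and the number of halogens, and the step still stays within the scatter. No available evidence accounts for how close these numbers lie.

The compounds shown all keep a substituted phenyl on the saturated chain carbon bound to an oxygen on an aromatic ring, so they do not show what a phenyl carrying an amine or a carboxylic acid would give. They also leave open whether a longer chain to the phenyl would produce a step beyond the scatter.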